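The source may report more compounds than this note shows. Statements on the series, on what has been measured and on what is new or still open speak of the compounds shown alone.

Compound 1 `CCCOC(=O)c1ccc(NC(=O)c2cccc(-c3cc(C(=O)Nc4ccncc4F)ccc3CN)c2)cc1` — < 1 nM
Compound 2 `COC(=O)c1ccc(F)c(C(=O)Nc2cccc(-c3cc(C(=O)Nc4ccncc4F)ccc3CN)c2)c1` — < 1 nM

Of the compounds shown here, two share a core and have been tested in an assay on cells for inhibition of Rho-associated protein kinase 2 (Homo sapiens), read by radiometric assay and 33P incorporation, in the presence of a further agent that is not named here; on this read-out lower numbers stand for stronger inhibition and higher numbers for weaker inhibition. In this assay compound 1 gives < 1 nM, which is a limit of the assay rather than a measured number. In this assay compound 2 likewise gives < 1 nM, again a limit. Compound 1 therefore stands at the limit of < 1 nM in this assay, at which 2 of the 2 values shown sit, so no ordering between the two measured compounds can be read from these results.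

Compound 3 `NCc1ccc(C(=O)Nc2ccncc2F)cc1-c1cccc(C(=O)Nc2ccccc2)c1` has not yet been measured in this assay. It differs from compound 1 in one place: hydrogen in place of propoxycarbonyl on an aromatic carbon. The same change, described one bond further out, reads 4-(propoxycarbonyl)phenyl to phenyl.

Among the compounds with values here, with both measured values sitting at a limit, no measured step is available to calibrate this change. Taking away a group of this size from a compound that is already at the limit is expected to cost some inhibition, so the step from compound 1 to compound 3 is estimated at an at least 3.0-fold higher number from compound 1 to compound 3 (0.47 log units; beyond the scatter), a weakening of modest size. Compound 3 is expected to give about 3 nM in this assay, within a range of 0.5 nM to 20 nM.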

Compound 3, half-maximal inhibitory concentration: < 1 nM
Compound 3 was reported as a limit; the forecaster's own chance of this, stated with the estimate: 30%; middle value at least 3.0-fold (0.47 log units) away from the limit.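

In this assay compound 3 gives < 1 nM, which is a limit and not a number. The step from compound 1 to compound 3 therefore cannot be read, as all the values sit at one limit: the limit of < 1 nM in this assay, at which 3 of the 3 values shown sit.

The compounds shown leave open whether replacing propoxycarbonyl with hydrogen changes inhibition at all, and by how much.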